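This account rests on a few compounds, and the source may have more. Where it says the series, first, only, none or still open, it means among the compounds named here.

Measured so far in a functional assay on MCF7 cells (Homo sapiens) for antiproliferative activity, read by sulforhodamine B assay, with a stated time of 72 h; on this read-out higher numbers stand for weaker inhibition and lower numbers for stronger inhibition:
compound 1 `COc1ncc(-c2ccc3ncnc(Nc4ccc(OCCO)cc4)c3c2)cc1NS(=O)(=O)c1ccc(F)cc1F` — 1650 nM
compound 2 `COc1ncc(-c2ccc3ncnc(Nc4ccc(OCCCO)nc4)c3c2)cc1NS(=O)(=O)c1ccc(F)cc1F` — 6120 nM

Among the compounds with values here, compound 2 stands at the higher of the two numbers; its only measured neighbour is compound 1, and the step of a 3.7-fold higher number from compound 1 to compound 2 (0.57 log units; beyond the scatter) separates the two. Compound 3 `COc1ncc(-c2ccc3ncnc(Nc4ccc(OCCO)c(F)c4)c3c2)cc1NS(=O)(=O)c1ccc(F)cc1F` has not yet been measured in this assay. The change that leads to it is 3-fluoro-4-(2-hydroxyethoxy)phenyl in place of 6-(3-hydroxypropoxy)pyridin-3-yl on a nitrogen on an aromatic ring. Within the data shown here, only one measured step bears on this change: a 3.7-fold higher number from compound 1 to compound 2 (0.57 log units; beyond the scatter) covers the exchange of 4-(2-hydroxyethoxy)phenyl for 6-(3-hydroxypropoxy)pyridin-3-yl on the same nitrogen, and the step from compound 2 to compound 3 undoes that exchange while also bringing in the fluorine of the 3-fluoro-4-(2-hydroxyethoxy)phenyl group. Nothing measured speaks to that fluorine, so it carries no expectation of its own. On the measured step alone, compound 3 is expected to return toward the number of compound 1, a step of a 3.8-fold lower number from compound 2 to compound 3 (0.58 log units; beyond the scatter) in this assay. The estimate for compound 3 is 1600 nM, with a range from 500 nM to 5000 nM.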

Compound 3, half-maximal inhibitory concentration: 4820 nM
For compound 3 the middle estimate is 3.0-fold (0.48 log units) below the measured one; the measured number falls inside the stated range.
By their numbers in this assay, from the lowest: compound 1; then compounds 3 and 2 (each within the scatter of the next).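

Notes on the group on the nitrogen, in this assay: fluoro in place of hydrogen on an aromatic carbon is the first change here confined to one atom, and it gives a 2.9-fold higher number from compound 1 to compound 3 (0.47 log units; beyond the scatter), a modest step beyond the scatter. The exchange of 6-(3-hydroxypropoxy)pyridin-3-yl for 3-fluoro-4-(2-hydroxyethoxy)phenyl gives a 1.3-fold lower number from compound 2 to compound 3 (0.10 log units; within the scatter), so these two groups cannot be told apart on this read-out, and the carbon-only ring with its 2-hydroxyethoxy chain does not by itself keep the number of compound 1 once the fluorine is present. Nothing measured on these compounds accounts for the fluorine step or for the closeness of the other pair.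

The step from compound 1 to compound 2 changes the ring and the chain together, so a 3-hydroxypropoxy chain on the carbon-only ring or a 2-hydroxyethoxy chain on the pyridine ring would be needed to separate the two contributions. Also open, on these data alone, is whether the fluorine step is specific to fluorine or would recur with a chlorine or a methyl group in its place, and how an amine or a carboxylic acid in place of the hydroxy group would read.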